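A few compounds are considered here, and "the series" means these few. Any claim that something is new, unique, unknown or untested is made for them only; others in the source may bear on it.

Measured compounds in an assay on microsomes for inhibition of Amine oxidase [flavin-containing] A (Homo sapiens), read by fluorescence and spectrophotometry, with a stated time of 20 min; a lower number here means a stronger inhibitor, a higher number a weaker inhibitor:

Compound 1 `Cn1c(=O)c2c(nc(SCCc3ccc(F)cc3)n2C)n(C)c1=O` gives 14700 nM.
Compound 2 `Cn1c(=O)c2c(nc([S+]([O-])CCc3ccc(F)cc3)n2C)n(C)c1=O` gives 239000 nM.
Compound 3 `Cn1c(=O)c2c(nc(SCCCc3cccc(Cl)c3)n2C)n(C)c1=O` gives 3530 nM.

Among these three numbers, compound 1 sits in the middle: compound 2 gives a higher number, and compound 3 gives a lower one. The measured step that points most clearly in one direction is a 4.2-fold lower number from compound 1 to compound 3 (0.62 log units; beyond the scatter), which shows that exchanging the 4-fluorophenyl end group for a 3-chlorobenzyl end group brings a modest gain.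

The new compound, compound 4 `Cn1c(=O)c2c(nc(SCc3cccc(Br)c3)n2C)n(C)c1=O`, is made from compound 1 by the change (3-bromophenyl in place of 4-fluorobenzyl on a saturated chain carbon bound to a sulfur). Going by the values given here, this is not the same move as the one to compound 3. The ring again carries a halogen at the 3-position, which matches the direction of the gain seen in compound 3, but here the chain between the sulfur and the ring is shorter, and nothing in the three measured compounds tells how much a shorter chain matters. Compound 2 does not help, since it changes the sulfur and not the chain.

On this basis only a modest gain is expected for compound 4, with wide uncertainty: the estimated step is a 1.8-fold lower number from compound 1 to compound 4 (0.26 log units; within the scatter), giving an expected value of 8000 nM, in a range from 2000 nM to 30000 nM.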

Compound 4, half-maximal inhibitory concentration: 37900 nM
The estimate for compound 4 lay 4.7-fold (0.68 log units) below the measured number, and the stated range ends below it.
By their numbers in this assay, from the lowest: compound 3; then compound 1; then compound 4; then compound 2.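

Compound 4 shows that this end of the molecule can shift the result in either direction in this assay: placing 3-bromophenyl on the saturated chain carbon bound to a sulfur gives a 2.6-fold higher number from compound 1 to compound 4 (0.41 log units; beyond the scatter) and is a modest loss, whereas the other change from the same parent gives a 4.2-fold lower number from compound 1 to compound 3 (0.62 log units; beyond the scatter) and is a modest gain. A halogen-bearing ring at the end of the chain therefore does not bring a gain on its own, since the 3-chlorobenzyl and 3-bromophenyl end groups move the number in opposite directions. Nothing measured here explains this reversal.

The change to compound 4 alters the halogen, its place on the ring and the chain length all at once, so the compounds shown cannot say which of these accounts for the loss. Going by these compounds, a 3-chlorophenyl group at this same carbon would separate the halogen from the chain length, and a 3-bromobenzyl group on the longer chain would test the same question from the other side, while an amine or a carboxylic acid on the ring remains unexplored here.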